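The compounds below may be only part of what the source reports. "The series", "measured", "known", "first", "only" and "open" are said of these compounds alone.

Measured compounds:
compound 1 `C/C=C/C(=O)N(Cc1ccc(OC)c([N+](=O)[O-])c1)c1cc(OC)c(OC)c(OC)c1` – 590 nM
compound 2 `CCC/C=C/C(=O)N(Cc1ccc(OC)c(O)c1)c1cc(OC)c(OC)c(OC)c1` – 70 nM
compound 3 `C/C=C/C(=O)N(Cc1ccc(OC)cc1)c1cc(OC)c(OC)c(OC)c1` – 450 nM

In a functional assay on MGC-803 cells (Homo sapiens) for inhibition, read by MTT assay, with a stated time of 48 h (on this read-out lower numbers stand for stronger inhibition and higher numbers for weaker inhibition), compound 2 gives the lowest number of the three, with compound 3 the nearest of the others and compound 1 the furthest; both gaps lie beyond the scatter. Among the measured compounds shown here, the one single-point step among the measured compounds, a 1.3-fold lower number from compound 1 to compound 3 (0.12 log units; within the scatter), concerns the aromatic ring of the benzyl part and lies within the scatter.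

Compound 4 `COc1ccc(CN(C(=O)CBr)c2cc(OC)c(OC)c(OC)c2)cc1O` is not yet measured. It differs from compound 2 at the acyl side: bromomethyl in place of pent-1-en-1-yl on a carbonyl carbon. No measured step touches this carbonyl carbon, so nothing among the shown compounds tells how exchanging a (pent-1-en-1-yl)carbonyl for a (bromomethyl)carbonyl will move the number; the step from compound 1 to compound 3 is of no help here. The expectation therefore rests on the value of compound 2 alone, 70 nM, and carries a wide range. Compound 4 is estimated at 250 nM, between 40 nM and 1500 nM, which would mean an expected step of a 3.6-fold higher number from compound 2 to compound 4 (0.55 log units; beyond the scatter).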

Compound 4, half-maximal inhibitory concentration: 140 nM
Beside the measured number, compound 4's estimate is 1.8-fold (0.25 log units) above it; the range from low to high includes it.
By their numbers in this assay, from the lowest: compounds 2 and 4 (each within the scatter of the next); then compounds 3 and 1 (each within the scatter of the next).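

In this assay, among the compounds shown here, the first reading at the carbonyl carbon gives a 2.0-fold higher number from compound 2 to compound 4 (0.30 log units; within the scatter), so this pair does not separate bromomethyl from pent-1-en-1-yl at this place. With the core of compound 2 otherwise unchanged, the acyl side therefore keeps its number within the scatter when the 5-carbon chain and its double bond give way to a group of 2 heavy atoms, 1 carbon and 1 bromine. Nothing shown gives a reason for this outcome.

On these data alone, whether this holds for the bromine itself remains open, as a plain methyl or a chloromethyl on the carbonyl carbon would be needed to test it. Also open, as far as these compounds go, is how an aminomethyl group or a longer chain at this place would read against compound 2 and compound 4.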